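This account rests on a few compounds, and the source may have more. Where it says the series, first, only, none or still open, it means among the compounds named here.

Compound 2 `COc1ccc(-c2cc(/C=C/C(=O)c3ccc(C)c(C)c3)nc3cc(-c4ccccc4)nn23)cc1OC` gives 46200 nM in an ADME assay on HEK293 cells (Homo sapiens) for antiproliferative activity, read by MTT assay, with a stated time of 24 h; a higher number here means a weaker inhibitor, a lower number a stronger inhibitor. Compound 1 `COc1ccc(/C=C/C(=O)c2cc(-c3ccc(OC)c(OC)c3)n3nc(-c4ccccc4)cc3n2)cc1` differs from it by (2-(4-methoxyphenyl)ethenyl)carbonyl in place of 2-((3,4-dimethylphenyl)carbonyl)ethenyl on an aromatic carbon, and in this assay compound 1 gives 50700 nM, so that a 1.1-fold higher number from compound 2 to compound 1 (0.04 log units; within the scatter). Compound 3 `COc1cc(-c2cc(/C=C/C(=O)c3ccc(C)c(C)c3)nc3cc(-c4ccccc4)nn23)cc(OC)c1OC` carries a different core, the difference being (methoxy in place of hydrogen on an aromatic carbon). In this assay compound 3 gives 72500 nM, with a 1.6-fold higher number from compound 2 to compound 3 (0.20 log units; within the scatter). Compound 4 `COc1ccc(/C=C/C(=O)c2cc(-c3cc(OC)c(OC)c(OC)c3)n3nc(-c4ccccc4)cc3n2)cc1`, not yet measured, differs from compound 3 by (2-(4-methoxyphenyl)ethenyl)carbonyl in place of 2-((3,4-dimethylphenyl)carbonyl)ethenyl on an aromatic carbon; this is the same kind of change as that from compound 2 to compound 1, but the place differs, being meta to a 3,4,5-trimethoxyphenyl group rather than meta to a 3,4-dimethoxyphenyl group. Because a 1.1-fold higher number from compound 2 to compound 1 (0.04 log units; within the scatter) stayed within the scatter, the step from compound 3 to compound 4 in this assay is expected to be a 1.1-fold higher number from compound 3 to compound 4 (0.03 log units; within the scatter). Compound 4 is estimated at 78000 nM in this assay, likely between 40000 nM and 150000 nM.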

Compound 4, half-maximal inhibitory concentration: 46600 nM
Compound 4: middle estimate off by 1.7-fold (0.22 log units), on the high side, and the stated range covers the measured number.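

In this assay, placing (2-(4-methoxyphenyl)ethenyl)carbonyl where 2-((3,4-dimethylphenyl)carbonyl)ethenyl stood gives a 1.6-fold lower number from compound 3 to compound 4 (0.19 log units; within the scatter), and the two instances of this change agree within the scatter: the same change on two cores in this assay, a 1.1-fold higher number (0.04 log units; within the scatter) from compound 2 to compound 1 and a 1.6-fold lower number (0.19 log units; within the scatter) from compound 3 to compound 4, 1.7-fold (0.23 log units) apart, within the scatter of two such steps. Methoxy in place of hydrogen on an aromatic carbon gives a 1.1-fold lower number from compound 1 to compound 4 (0.04 log units; within the scatter), and this change also agrees across its two instances: the same change on two cores in this assay, a 1.6-fold higher number (0.20 log units; within the scatter) from compound 2 to compound 3 and a 1.1-fold lower number (0.04 log units; within the scatter) from compound 1 to compound 4, 1.7-fold (0.23 log units) apart, within the scatter of two such steps. With every step inside the scatter, the four compounds show that neither change has a measurable effect on these two cores, but they do not show that a change with a real effect would carry over from one core to another.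

From the compounds shown here alone, it remains open whether an amine or a carboxylic acid in place of a methoxy group would give a step beyond the scatter.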